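The source may hold more compounds than are shown below. What is called first, only, known or untested is meant among the compounds shown, and "the series" means these compounds.

Measured so far:
compound 1 `CC1(C)CC12NC(=O)N(NC(=O)c1ccccc1)C2=O` — 300 mg/kg
compound 2 `CC1(C)CC12NC(=O)N(NC(=O)c1ccc(Cl)cc1)C2=O` — 300 mg/kg
compound 3 `CC1(C)CC12NC(=O)N(NC(=O)c1ccc([N+](=O)[O-])cc1)C2=O` — 300 mg/kg

In a functional assay on the whole organism for inhibition, with Mus musculus as the target, with a stated time of 0.5 h (on this read-out higher numbers stand for an effect only at larger amounts of compound and lower numbers for an effect already at smaller amounts), compound 3 gives 300 mg/kg, level with compounds 1 and 2. Compound 4 `CN(C)c1ccc(C(=O)NN2C(=O)NC3(CC3(C)C)C2=O)cc1` differs from compound 3 in one place: dimethylamino in place of nitro on an aromatic carbon. Going by the values given here, the steps that bear on this are the earlier changes at the same aromatic carbon: no change at the digits printed from compound 1 to compound 3 (within the scatter) and no change at the digits printed from compound 2 to compound 3 (within the scatter), and also no change at the digits printed from compound 1 to compound 2 (within the scatter). Three different substituents at that carbon have left this assay unchanged, so no step beyond the scatter is expected for a dimethylamino group there either. Compound 4 is therefore expected to give 300 mg/kg, within 150 mg/kg to 600 mg/kg, an expected step of no change at the digits printed from compound 3 to compound 4 (within the scatter).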

Compound 4, minimum effective dose: 100 mg/kg
The estimate for compound 4 lay 3.0-fold (0.48 log units) above the measured number, outside the stated range (below it).
By their numbers in this assay, from the lowest: compound 4; then compounds 1, 2 and 3 (each within the scatter of the next).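

In this assay, going by these compounds alone, this aromatic carbon is no longer silent: hydrogen, chloro and nitro there stay level, but dimethylamino is the first group to move the read-out beyond the scatter (a 3.0-fold lower number from compound 3 to compound 4 (0.48 log units; beyond the scatter)) (also a 3.0-fold lower number from compound 2 to compound 4 (0.48 log units; beyond the scatter)) (and a 3.0-fold lower number from compound 1 to compound 4 (0.48 log units; beyond the scatter)). The gain is modest and rests on compound 4 alone. Nothing at hand accounts for the shift.

As far as these compounds go, whether it is specific to dimethylamino remains open. A primary amine, a methoxy group or a longer diethylamino chain at the same carbon would test how far it extends.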